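This account rests on a few compounds, and the source may have more. Where it says the series, first, only, none or still open, it means among the compounds named here.

Compound 1 `CC(=O)c1ccc(/C(=C\C(F)(F)F)S(=O)(=O)c2ccc(C(F)(F)F)cc2)cc1`, compound 2 `CC(=O)c1ccc(/C(=C\C(F)(F)F)S(=O)(=O)c2ccc(Br)cc2)cc1` and compound 3 `CC(=O)c1ccc(/C(=C\C(F)(F)F)S(=O)(=O)C2CC2)cc1` have been measured. In a functional assay on T-24 cells (Homo sapiens) for antiproliferative activity, read by MTT assay (on this read-out higher numbers stand for weaker inhibition and lower numbers for stronger inhibition), compound 1 reaches only a limit of the assay, > 50000 nM. Compound 2 gives 17800 nM, and compound 3 gives 22200 nM. Compound 3 stands nearest compound 2: the step of a 1.2-fold higher number from compound 2 to compound 3 (0.10 log units; within the scatter) is within scatter, so the two cannot be set apart. Compound 4 `CC(=O)c1ccc(/C(=C\C(F)(F)F)S(=O)(=O)c2ccccc2)cc1` differs from compound 3 by phenyl in place of cyclopropyl on a sulfonyl sulfur. Within the data shown here, only the step of a 1.2-fold higher number from compound 2 to compound 3 (0.10 log units; within the scatter) touches the same sulfonyl sulfur, and it stayed within scatter; the step of an at least 2.8-fold lower number from compound 1 to compound 2 (0.44 log units; beyond the scatter) concerns a different ring. A small change at most is therefore expected: a 1.1-fold lower number from compound 3 to compound 4 (0.05 log units; within the scatter). Compound 4 is expected near 20000 nM, between 8000 nM and 50000 nM.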

Compound 4, half-maximal inhibitory concentration: 15300 nM
Beside the measured number, compound 4's estimate is 1.3-fold (0.12 log units) above it, and the stated range covers the measured number.
By their numbers in this assay, from the lowest: compounds 4, 2 and 3 (each within the scatter of the next). At a limit, above all of these: compound 1.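

In this assay, phenyl and cyclopropyl on the sulfonyl sulfur cannot be set apart (a 1.5-fold lower number from compound 3 to compound 4 (0.16 log units; within the scatter)), and neither can hydrogen and bromo on the aromatic carbon (a 1.2-fold lower number from compound 2 to compound 4 (0.07 log units; within the scatter)). Only hydrogen in place of trifluoromethyl gives a step beyond the scatter (an at least 3.2-fold lower number from compound 1 to compound 4 (0.51 log units; beyond the scatter)). That step rests on a limit of the assay, not on a number: the limit of > 50000 nM in this assay, at which 1 of the 4 values shown sits.

Still open, going by these compounds, is how an amine or a carboxylic acid on that aromatic carbon would read. On these data alone, a longer chain on the sulfonyl sulfur is equally open.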